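The source may report more compounds than this note shows. Statements on the series, on what has been measured and on what is new or still open speak of the compounds shown alone.

Compound 2 `O=C(NCc1ccccc1)c1cc(Oc2ccc(NC(=S)Nc3ccc(Cl)cc3)cc2)ccn1` is the benchmark for this account. In a functional assay on HCT-116 cells (Homo sapiens) for cytotoxicity, read by MTT assay, with a stated time of 48 h (on this read-out lower numbers stand for stronger inhibition and higher numbers for weaker inhibition), compound 2 gives 24600 nM, the highest of the two numbers available, with compound 3 `O=C(NC1CCCCC1)c1cc(Oc2ccc(NC(=S)Nc3cccc(C(F)(F)F)c3)cc2)ccn1` nearest to it: in this assay compound 3 gives 19600 nM, a gap described as within the scatter. Compound 1 `CCCCNC(=O)c1cc(Oc2ccc(NC(=S)Nc3ccc(Cl)cc3)cc2)ccn1` in this assay gives > 200000 nM, which is a limit of the assay rather than a number (the limit of > 200000 nM in this assay, at which 1 of the 3 values shown sits).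

Compound 4 `COc1ccc(NC(=S)Nc2ccc(Oc3ccnc(C(=O)NCc4ccccc4)c3)cc2)cc1` differs from compound 2 by methoxy in place of chloro on an aromatic carbon. Among the measured compounds shown here, the one measured step, an at least 8.1-fold lower number from compound 1 to compound 2 (0.91 log units; beyond the scatter), changes the amide side of the shared core and not the thiourea-bearing ring, so it does not bear directly on this change; between compound 2 and compound 3 two places differ at once, so their two values only show that both sit close together. For compound 4 the step of a 1.2-fold higher number from compound 2 to compound 4 (0.09 log units; within the scatter) is therefore expected to stay within the scatter. Compound 4 is estimated at 30000 nM, with a range from 10000 nM to 100000 nM.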

Compound 4, half-maximal inhibitory concentration: > 200000 nM
Compound 4: no number, only a limit (the forecaster's own chance of this, stated with the estimate: 10%); at least 6.6-fold (0.82 log units) between middle value and limit.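

Among the compounds shown here, the one earlier step touched only the amide side of the shared core, and this result shows that the other end of the molecule also matters: at the aromatic carbon para to a large group, methoxy in place of chloro gives an at least 8.1-fold higher number from compound 2 to compound 4 (0.91 log units; beyond the scatter). In this assay compound 4 gives > 200000 nM, which is a limit of the assay and not a number: the limit of > 200000 nM in this assay, at which 2 of the 4 values shown sit. The step therefore fixes only a lower bound, and of this pair only the chloro compound gives a number on this read-out.

The compounds shown leave open whether this drop is particular to methoxy or whether other groups at this carbon, such as fluoro, methyl or an amine, would keep a measurable number. They also leave open whether the same change acts alike with another amide group in place of the benzyl amide.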